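This account rests on a few compounds, and the source may have more. Where it says the series, first, only, none or still open, it means among the compounds named here.

Compound 1 `Cc1cc(CCC(=O)O)ccc1-c1noc(-c2ccc(OC(C)C)c(F)c2)n1` gives 530 nM in a functional assay on CHO cells for agonist activity at sphingosine 1-phosphate receptor 5 (Homo sapiens), read by GTPgammaS binding; a lower number here means that less compound is needed, a higher number that more compound is needed for the effect.
Compound 2 `CC[C@H](C)Oc1ccc(-c2nc(-c3ccc(CCC(=O)O)cc3C)no2)cc1C#N` gives 15 nM in this assay.
Compound 3 `Cc1cc(CCC(=O)O)ccc1-c1noc(-c2ccc(OC(C)C(F)(F)F)c(C#N)c2)n1` gives 3.1 nM in this assay.

Compound 3 has the lowest number of the three. Its nearest neighbour is compound 2, and the single-change step between them, a 4.8-fold lower number from compound 2 to compound 3 (0.68 log units; beyond the scatter), shows how far they sit apart; compound 1 lies much further up. Compound 4 `Cc1cc(CCC(=O)O)ccc1-c1noc(-c2ccc(OCC(F)(F)F)c(C#N)c2)n1` is the next step from compound 3: hydrogen in place of methyl on a saturated chain carbon bound to an oxygen on an aromatic ring and a saturated chain carbon. Within the data shown here, none of the measured steps concerns this particular change. Among the measured compounds shown here, the one step that was measured, a 4.8-fold lower number from compound 2 to compound 3 (0.68 log units; beyond the scatter), replaced one alkoxy side group with another on the same oxygen, so it touches the same region but is a different substitution. Trimming a methyl from that chain is therefore expected to move the number only a little, most likely within the scatter or a slight rise. Compound 4 is expected to give 6 nM, with a range from 2 nM to 20 nM. The expected step is a 1.9-fold higher number from compound 3 to compound 4 (0.29 log units; within the scatter).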

Compound 4, half-maximal effective concentration: 44 nM
The estimate for compound 4 lay 7.3-fold (0.87 log units) below the measured number, outside the stated range (above it).
By their numbers in this assay, from the lowest: compound 3; then compound 2; then compound 4; then compound 1.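

Removing just one methyl, a change of 1 heavy atom on the saturated chain carbon bound to the oxygen on the aromatic ring, gives a 14-fold higher number from compound 3 to compound 4 (1.15 log units; beyond the scatter) in this assay, so this carbon is far from indifferent to a small edit. The second comparison, a 2.9-fold higher number from compound 2 to compound 4 (0.47 log units; beyond the scatter), shows that the 2,2,2-trifluoroethyl group, despite keeping the trifluoromethyl of compound 3, does not match the sec-butyl group of compound 2. Nothing shown here explains why this methyl matters so much.

The compounds shown leave open whether a longer chain, such as an ethyl in place of that methyl, would hold or lower the number. They also leave open whether the two mirror-image forms of compound 3, which is drawn without a defined arrangement at that carbon, behave alike.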